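This account rests on a few compounds, and the source may have more. Where it says the series, first, only, none or still open, it means among the compounds named here.

Measured compounds:
compound 1, `O=C(/C=C/c1ccc([N+](=O)[O-])cc1)Nc1cc2c(Nc3ccc(F)c(Cl)c3)ncnc2cc1O[C@H]1CCOC1`, 22800 nM
compound 2, `COc1cc(/C=C/C(=O)Nc2cc3c(Nc4ccc(F)c(Cl)c4)ncnc3cc2OC)cc(OC)c1`, "not active" (no number reported)

Among the measured compounds shown here, in a functional assay on PC-3 cells (Homo sapiens) for cytotoxicity, read by MTT assay, with a stated time of 72 h (on this read-out higher numbers stand for weaker inhibition and lower numbers for stronger inhibition), compound 1 gives 22800 nM, the only numerical value recorded; compound 2 is reported as "not active" (no number reported) without a number. Compound 3, `O=C(/C=C/c1ccc(Br)cc1)Nc1cc2c(Nc3ccc(F)c(Cl)c3)ncnc2cc1O[C@H]1CCOC1`, shares the core of compound 1 and differs from it only as bromo in place of nitro on an aromatic carbon. For the measured compounds named here, no measured pair shows this change, so no step size can be read from the data. The expected change from compound 1 to compound 3 is a 1.5-fold lower number from compound 1 to compound 3 (0.18 log units; within the scatter), within the usual scatter. The estimated value for compound 3 is 15000 nM, between 5000 nM and 50000 nM.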

Compound 3, half-maximal inhibitory concentration: 28200 nM
The estimate for compound 3 lay 1.9-fold (0.27 log units) below the measured number; measured number inside the range.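

In this assay, replacing nitro with bromo on the aromatic ring gives a 1.2-fold higher number from compound 1 to compound 3 (0.09 log units; within the scatter), so compound 1 and compound 3 cannot be told apart. Among the compounds shown here, this is the first direct reading at this position: here, a single bromine atom in place of the three heavy atoms of nitro makes no measurable difference. No measured evidence explains this result. As far as these compounds go, whether an amine or a carboxylic acid at this position would also fall within the scatter remains open, so these two groups alone set no rule for the position.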